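The source may hold more compounds than are shown below. What is called first, only, known or untested is meant among the compounds shown, and "the series" means these compounds.

Measured compounds:
- compound 1 `Nc1nc(Cl)c2ncn(Cc3ccc(CCl)cc3)c2n1`: 91200 nM
- compound 2 `ClCc1cccc(Cn2cnc3c(Cl)nc(Cl)nc32)c1`: 7240 nM
- compound 3 `ClCc1ccc(Cn2cnc3c(Cl)nc(Cl)nc32)cc1`: 7240 nM

In a functional assay on MDA-MB-231 cells (Homo sapiens) for cytotoxicity, read by sulforhodamine B assay, with a stated time of 48 h (on this read-out higher numbers stand for lower toxicity in this test and lower numbers for higher toxicity in this test), compound 3 gives 7240 nM and compound 2 gives 7240 nM; the two numbers agree at the digits given, so nothing separates them in this assay. Compound 2 and compound 3 are built from the same atoms joined differently; the difference between the two cores is not broken down here.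

Compound 1 differs from compound 3 by one change, (amino in place of chloro on an aromatic carbon), and this step is large: a 13-fold higher number from compound 3 to compound 1 (1.10 log units; beyond the scatter). Among the measured compounds shown here, it is the only occurrence of that change among the measured compounds, so its size rests on a single pair.

Compound 4 `Nc1nc(Cl)c2ncn(Cc3cccc(CCl)c3)c2n1` has not yet been measured in this assay. It relates to compound 2 as compound 1 relates to compound 3, by the change (amino in place of chloro on an aromatic carbon). The place of the change reads word for word the same in both pairs, so the change is the same, applied to a different core.

Compound 4 is expected to follow the earlier step, so a step of about a 12-fold higher number from compound 2 to compound 4 (1.09 log units; beyond the scatter) is estimated, because compound 2 starts at 7240 nM and the same change moved compound 3 to compound 1 by a 13-fold higher number from compound 3 to compound 1 (1.10 log units; beyond the scatter). For compound 4 the estimate is 90000 nM, with a likely range from 30000 nM to 250000 nM, and a real chance that the assay reports only a limit at this level.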

Compound 4, concentration lethal to 50% of the cells: 69200 nM
For compound 4 the middle estimate is 1.3-fold (0.11 log units) above the measured one; the measured number falls inside the stated range.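

In this assay, amino in place of chloro on an aromatic carbon again goes with a higher number, and on the second core the step is a 9.6-fold higher number from compound 2 to compound 4 (0.98 log units; beyond the scatter). The change therefore carries from one core to the other with no size difference that can be told apart, and the two steps can be treated as one repeated effect in this small set: the same change on two cores in this assay, a 13-fold higher number (1.10 log units; beyond the scatter) from compound 3 to compound 1 and a 9.6-fold higher number (0.98 log units; beyond the scatter) from compound 2 to compound 4, 1.3-fold (0.12 log units) apart, within the scatter of two such steps. This shows transfer between these two closely related cores only, which are built from the same atoms joined differently, so it rests on two pairs in this assay and does not show that the step would keep its size on a more distant core, nor does it give any reason for the step.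

The compounds shown leave open whether another group in the same place, such as a methylamino, a hydroxyl or a methoxy group, would give a step like that of the amino group. They also leave open how the numbers would respond if the chloromethyl group gave way to a plain methyl or a hydroxymethyl group, or if the remaining chloro group were replaced by an amine.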